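A few compounds are considered here, and "the series" means these few. Any claim that something is new, unique, unknown or untested is made for them only; others in the source may bear on it.

Compound 2 `CCON(C)C(=O)c1sc(-c2ccccc2O)nc1O` holds the higher of the two numbers recorded so far. In an assay on HEK293 cells for inhibition of transient receptor potential cation channel subfamily M member 8 (Homo sapiens), read by FLIPR, with stated times of 5 min and 3 min (on this read-out higher numbers stand for weaker inhibition and lower numbers for stronger inhibition), compound 2 gives 1500 nM, while compound 1 `O=C(c1sc(-c2ccccc2O)nc1O)N1CCCCO1` gives 81 nM. Among the compounds with values here, the one recorded step, a 19-fold higher number from compound 1 to compound 2 (1.27 log units; beyond the scatter), comes from replacing the six-membered ring on the carbonyl carbon with an open chain, and compound 2 is the weaker inhibitor of the pair by a margin well beyond the scatter.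

Compound 3 `CON(C)C(=O)c1sc(-c2ccccc2O)nc1O` is the next compound. It differs from compound 2 by hydrogen in place of methyl on a saturated chain carbon bound to an oxygen on an unsaturated carbon, so that ethoxy becomes methoxy. Within the data shown here, no measured step removes a single carbon from such a chain; the only step recorded, from compound 1 to compound 2, concerns the ring and does not directly speak to it. Shortening a chain by one carbon is a small change, and compound 3 is therefore expected to stay close to compound 2, with a step of about no change at the digits printed from compound 2 to compound 3 (within the scatter) in this assay, not clearly beyond the scatter in either direction. The estimate for compound 3 in this assay is 1500 nM, within a range from 500 nM to 4500 nM.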

Compound 3, half-maximal inhibitory concentration: 66 nM
Compound 3: the middle estimate sits 23-fold (1.36 log units) above what was measured; the whole stated range lies above it.
By their numbers in this assay, from the lowest: compounds 3 and 1 (each within the scatter of the next); then compound 2.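

In this assay, the change from ethoxy(methyl)amino to methoxy(methyl)amino, which removes a single methyl, gives a 23-fold lower number from compound 2 to compound 3 (1.36 log units; beyond the scatter), so this position responds strongly to even a one-carbon change. The open chain is also compatible with a low number: replacing the six-membered ring with the methoxy(methyl)amino group gives a 1.2-fold lower number from compound 1 to compound 3 (0.09 log units; within the scatter), so the ring is not needed for that level of inhibition. Nothing available here accounts for so large a step from one methyl. The compounds shown leave open how a longer chain such as propoxy, or a branched one such as isopropoxy, would read at this position. They also leave open whether an amine or a hydroxyl in place of methoxy would keep the low number.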